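Swapping a Ring Amine for an Open Chain Amine

The source may report more compounds than this note shows. Statements on the series, on what has been measured and on what is new or still open speak of the compounds shown alone.

Of the compounds shown here, three on a shared core have been measured: compound 1 `Cc1cc2[nH]nc(N)c2c(=O)[nH]1`, compound 2 `Cc1cc2c(c(N)nn2C)c(N2CCCCC2)n1` and compound 3 `Cc1cc2c(c(N)nn2C)c(N2CC[C@H](O)C2)n1`. In an assay on isolated protein for inhibition of serine/threonine-protein kinase D2 (Homo sapiens), read by mobility shift assay, tested at 30 uM (a higher number here means more inhibition at the concentration tested (going by the name of the read-out), a lower number less inhibition), compound 1 gives -1%, compound 2 gives 16% and compound 3 gives 8%. Compound 3 stands second highest of the three numbers, yet both its nearest neighbour, compound 2, and its furthest, compound 1, lie within the scatter of it, so no order among them can be claimed. Among the compounds with values here, the single measured step, a number 8 percentage points lower from compound 2 to compound 3 (within the scatter), is the only one that bears on exchanging the amine on that aromatic carbon.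

Compound 4 `COCCNc1nc(C)cc2c1c(N)nn2C` differs from compound 3 by (2-methoxyethyl)amino in place of 3-hydroxypyrrolidin-1-yl on an aromatic carbon. Because a number 8 percentage points lower from compound 2 to compound 3 (within the scatter) stayed within the scatter when one ring amine replaced another, no step beyond the scatter is expected for compound 4 in this assay. The estimate for compound 4 is therefore 8%, with a range from -6% to 22%. The expected step of no change at the digits printed from compound 3 to compound 4 (within the scatter) is thus small and within the scatter.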

Compound 4, a percentage reported as inhibition, at one concentration (the size of the read-out at that concentration, not a potency): 4%
The estimate for compound 4 lay 4 percentage points above the measured number, within the range that was stated.
By their numbers in this assay, from the lowest: compounds 1, 4, 3 and 2 (each within the scatter of the next, the first and the last beyond it).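

Within the data shown here, the open chain (2-methoxyethyl)amino is the first group without a ring at this aromatic carbon next to the ring nitrogen, and in this assay the exchange gives a number 4 percentage points lower from compound 3 to compound 4 (within the scatter), so losing the 3-hydroxypyrrolidin-1-yl ring and its defined stereocentre has no readable effect. Among these compounds, measured against piperidin-1-yl, the same open chain gives a number 12 percentage points lower from compound 2 to compound 4 (beyond the scatter), the first step at this position to pass the scatter, and a modest one. Compound 3 remains within the scatter of both compound 2 and compound 4, so only the two outer amines at this position can be told apart.

From the compounds shown here alone, whether an unsubstituted amine or a longer chain such as (3-methoxypropyl)amino would read differently at this position in this assay remains open. No evidence is available to explain the difference between the piperidin-1-yl and (2-methoxyethyl)amino compounds.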